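The compounds below may be only part of what the source reports. "The series", "measured", "known", "first", "only" and "open" are said of these compounds alone.

Measured compounds:
compound 1 `Cc1cn(C2CCN(Cc3cccc(Oc4cc(C(F)(F)F)cc(C(F)(F)F)c4)c3)CC2)c(=O)[nH]c1=O` — "not determined" (no result reported)
compound 2 `Cc1cn(C2CCN(Cc3cccc(Oc4ccc(Cl)cc4)c3)CC2)c(=O)[nH]c1=O` — 25100 nM

In an ADME assay on MRC5 cells (Homo sapiens) for cytotoxicity, read by fluorescence and resazurin assay, with a stated time of 3 days (on this read-out higher numbers stand for weaker inhibition and lower numbers for stronger inhibition), compound 2 gives 25100 nM; for compound 1 the result is "not determined" (no result reported), so compound 2 holds the only number shown. Compound 3 `Cc1cn(C2CCN(Cc3cccc(Oc4cccnc4)c3)CC2)c(=O)[nH]c1=O` is not yet measured in this assay. The change from compound 2 to compound 3 is pyridin-3-yl in place of 4-chlorophenyl on an oxygen on an aromatic ring. Going by the values given here, with no measured pair to learn from, the expected step of a 1.6-fold higher number from compound 2 to compound 3 (0.20 log units; within the scatter) is small, if anything toward weaker inhibition, and not clearly beyond the scatter. Compound 3 is estimated at 40000 nM, within 15000 nM to 110000 nM.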

Compound 3, half-maximal inhibitory concentration: > 64000 nM
Compound 3: no number, only a limit; the forecaster's own chance of this, stated with the estimate: 35%; at least 1.6-fold (0.20 log units) between middle value and limit.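

In this assay, going by these compounds alone, the change to pyridin-3-yl in place of 4-chlorophenyl on an oxygen on an aromatic ring gives the first readable step at this position, toward weaker inhibition: an at least 2.5-fold higher number from compound 2 to compound 3 (0.40 log units; beyond the scatter). Compound 3 gives > 64000 nM, which is a limit of the assay and not a number. The full size of the step therefore stays unknown, since the reading stops at a limit: the limit of > 64000 nM in this assay, at which 1 of the 3 values shown sits.

The compounds shown cannot separate the loss of the chlorine from the arrival of the ring nitrogen. From the compounds shown here alone, how a plain phenyl group on the same oxygen would read remains open.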